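One More Chain Carbon: What Compound 3 May Show

This account rests on a few compounds, and the source may have more. Where it says the series, first, only, none or still open, it means among the compounds named here.

- compound 1 `CCCCCCCCCCCOC1=C(O)OC(C(O)CO)C1=O` at 13000 nM
- compound 2 `CCCCCCCCCCCCOC1=C(O)OC(C(O)CO)C1=O` at 54000 nM

Both numbers come from a functional assay (brain) for inhibition, with Rattus norvegicus as the target (on this read-out higher numbers stand for weaker inhibition and lower numbers for stronger inhibition), where compound 2 holds the higher value, 54000 nM (the weaker inhibition of the two). Compound 3 `CCCCCCCCCCCCCOC1=C(O)OC(C(O)CO)C1=O` differs from compound 2 by methyl in place of hydrogen on a saturated chain carbon, ten or more bonds along the chain from an oxygen on an unsaturated carbon (methyl in place of hydrogen on a saturated chain carbon). The same kind of change has been measured only once (a 4.2-fold higher number from compound 1 to compound 2 (0.62 log units; beyond the scatter)), a modest step beyond the scatter. With that single precedent, a further rise of similar or somewhat smaller size is expected in this assay and so weaker inhibition. The expected step is a 2.2-fold higher number from compound 2 to compound 3 (0.35 log units; beyond the scatter) as an estimate. Compound 3 is estimated at 120000 nM (expected range 45000 nM to 320000 nM).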

Compound 3, half-maximal inhibitory concentration: 7400 nM
Beside the measured number, compound 3's estimate is 16-fold (1.21 log units) above it, and the stated range ends above it.
By their numbers in this assay, from the lowest: compounds 3 and 1 (each within the scatter of the next); then compound 2.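

In this assay, the same methyl change that raised the number one step earlier now runs the other way (a 7.3-fold lower number from compound 2 to compound 3 (0.86 log units; beyond the scatter)), so along this chain the change has no fixed direction. Compound 1 and compound 3 stay within the scatter of each other (a 1.8-fold lower number from compound 1 to compound 3 (0.24 log units; within the scatter)), which leaves compound 2 as the single high point of the three. Nothing measured here offers an explanation for this reversal.

As far as these compounds go, whether a longer chain would lower the number, raise it or leave it within the scatter remains open. So does the effect of an amine on the chain.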